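From 3-(trifluoromethyl)phenyl to 4-cyanophenyl in a growth-inhibition series

A few compounds are considered here, and "the series" means these few. Any claim that something is new, unique, unknown or untested is made for them only; others in the source may bear on it.

In a functional assay on A549 cells (Homo sapiens) for inhibition, read by CCK-8 assay, with a stated time of 72 h, tested at 1 uM (on this read-out lower numbers stand for less inhibition of growth and higher numbers for more inhibition of growth at the one concentration tested), compound 1 (`CN(C)C(=O)c1cc2cnc(Nc3ccc(NC(=O)C4(C(=O)Nc5ccccc5F)CC4)cc3)nc2n1C1CCCC1`), which carries 2-fluorophenyl on an amide-type nitrogen, gives 79.1%. On the same shared core, compound 2 (`CN(C)C(=O)c1cc2cnc(Nc3ccc(NC(=O)C4(C(=O)Nc5cccc(Cl)c5)CC4)cc3)nc2n1C1CCCC1`) gives 8.3% and compound 3 (`CN(C)C(=O)c1cc2cnc(Nc3ccc(NC(=O)C4(C(=O)Nc5cccc(C(F)(F)F)c5)CC4)cc3)nc2n1C1CCCC1`) gives 15.7%. These last two values stand level within the scatter, as the step of a number 7.4 percentage points higher from compound 2 to compound 3 (within the scatter) shows, and both lie far under compound 1. The steps there are a number 70.8 percentage points lower from compound 1 to compound 2 (beyond the scatter) and a number 63.4 percentage points lower from compound 1 to compound 3 (beyond the scatter).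

Compound 4 (`CN(C)C(=O)c1cc2cnc(Nc3ccc(NC(=O)C4(C(=O)Nc5ccc(C#N)cc5)CC4)cc3)nc2n1C1CCCC1`) has 4-cyanophenyl in place of 3-(trifluoromethyl)phenyl on an amide-type nitrogen. For the measured compounds named here, no measured compound carries 4-cyanophenyl, so the measured steps bear on this change only indirectly. The two large steps show that a change of this group can matter greatly, while the step between compound 2 and compound 3 stayed small. A modest rise, not a return towards compound 1, therefore seems most likely, though the uncertainty is wide. The expected step is a number 8.3 percentage points higher from compound 3 to compound 4 (within the scatter). For compound 4 the estimated value is 24%, within an expected range from 6% to 60%.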

Compound 4, percent growth inhibition at one concentration: 86.1%
Beside the measured number, compound 4's estimate is 62.1 percentage points below it; the measured number lies above the stated range.
By their numbers in this assay, from the lowest: compounds 2 and 3 (each within the scatter of the next); then compounds 1 and 4 (each within the scatter of the next).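

At this amide-type nitrogen, high growth inhibition is not confined to 2-fluorophenyl, since 4-cyanophenyl also gives it: the change is a number 70.4 percentage points higher from compound 3 to compound 4 (beyond the scatter) and, against the chloro analogue, a number 77.8 percentage points higher from compound 2 to compound 4 (beyond the scatter). The remaining step, a number 7 percentage points higher from compound 1 to compound 4 (within the scatter), leaves these two high values level. Among the four compounds, the two groups that give low values are 3-chlorophenyl and 3-(trifluoromethyl)phenyl, while 2-fluorophenyl and 4-cyanophenyl give high values, so a single change of this aryl group can move the value across nearly the whole range seen here.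

Nothing available accounts for this sharp split. Going by these compounds, whether it follows the place of the substituent or its identity remains open, as a 3-cyanophenyl or 4-chlorophenyl group would help separate the two, and how an aminophenyl or a carboxyphenyl group would stand is equally unsettled.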